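Furan Gives Way to Thiophene on the Hydrazone Carbon

A few compounds are considered here, and "the series" means these few. Any claim that something is new, unique, unknown or untested is made for them only; others in the source may bear on it.

Of the compounds shown here, two built on a shared core have been measured in a functional assay on PC-3 cells (Homo sapiens) for antiproliferative activity, read by MTT assay; a lower number here means a stronger inhibitor, a higher number a weaker inhibitor. Compound 1 `Cn1c(=O)c(=O)n(C2CCCC2)c2nc(N/N=C/c3ccc(C(F)(F)F)cc3)ncc21` carries 4-(trifluoromethyl)phenyl on a carbon with a double bond to nitrogen, and in this assay compound 1 gives 23600 nM. Compound 2 `Cn1c(=O)c(=O)n(C2CCCC2)c2nc(N/N=C/c3ccco3)ncc21` carries furan-2-yl at that place, and in this assay compound 2 gives 72200 nM. Compound 2 therefore stands at the higher of the two numbers, separated from compound 1 by a 3.1-fold higher number from compound 1 to compound 2 (0.49 log units; beyond the scatter).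

Compound 3 `Cn1c(=O)c(=O)n(C2CCCC2)c2nc(N/N=C/c3cccs3)ncc21` differs from compound 2 in one place: thiophen-2-yl in place of furan-2-yl on a carbon with a double bond to nitrogen. Among the compounds with values here, no measured step exchanges one five-membered aromatic ring for another; the only step available, a 3.1-fold higher number from compound 1 to compound 2 (0.49 log units; beyond the scatter), replaces 4-(trifluoromethyl)phenyl with furan-2-yl and so bears only loosely on this change. Because compound 2 gives 72200 nM and furan-2-yl and thiophen-2-yl match in size and in their single hetero atom, compound 3 is expected to land near compound 2, with an expected step of a 1.3-fold lower number from compound 2 to compound 3 (0.12 log units; within the scatter) that may well stay within the scatter. The estimate for compound 3 in this assay is 55000 nM, inside a range from 20000 nM to 150000 nM.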

Compound 3, half-maximal inhibitory concentration: 75600 nM
Estimate against measurement, compound 3: 1.4-fold (0.14 log units) below; measured number inside the range.
By their numbers in this assay, from the lowest: compound 1; then compounds 2 and 3 (each within the scatter of the next).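

In this assay, within the data shown here, thiophen-2-yl in place of furan-2-yl on a carbon with a double bond to nitrogen gives a 1.0-fold higher number from compound 2 to compound 3 (0.02 log units; within the scatter) and stays within the scatter, so sulfur and oxygen in this five-membered aromatic ring cannot be told apart here, something no earlier pair could show. The gap to the 4-(trifluoromethyl)phenyl compound also appears a second time, as a 3.2-fold higher number from compound 1 to compound 3 (0.51 log units; beyond the scatter) beside the earlier 3.1-fold higher number from compound 1 to compound 2 (0.49 log units; beyond the scatter), so it now holds for both five-membered rings, and none of the three compounds goes against it. Nothing measured here explains either the match between the two rings or their gap to compound 1.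

The compounds shown leave open whether that gap belongs to the phenyl ring or to its trifluoromethyl group, a question that plain phenyl or 4-methylphenyl at this place could help to separate. They also leave open whether this place stays as undemanding with a pyridine ring, or with a furan ring bearing an amine or a carboxylic acid.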